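Working notes: from compound 2 to compound 3

A few compounds are considered here, and "the series" means these few. Any claim that something is new, unique, unknown or untested is made for them only; others in the source may bear on it.

In a functional assay on NCI-H23 cells (Homo sapiens) for inhibition, read by sulforhodamine B assay, with a stated time of 48 h (a higher number here means a weaker inhibitor of growth, a lower number a stronger inhibitor of growth), compound 1 (`O=C(Cc1csc2nc(-c3ccc(Br)cc3)cn12)N/N=C/c1ccccc1`) gives 12600 nM and compound 2 (`O=C(Cc1csc2nc(-c3ccc(Br)cc3)cn12)N/N=C/c1ccc(O)cc1`) gives 7590 nM with the two within the scatter of each other. Compound 3 (`COc1cccc(OC)c1/C=N/NC(=O)Cc1csc2nc(-c3ccc(Br)cc3)cn12`) differs from compound 2 by 2,6-dimethoxyphenyl in place of 4-hydroxyphenyl on a carbon with a double bond to nitrogen on a carbon with a double bond to nitrogen. Among the compounds with values here, the one measured step, a 1.7-fold lower number from compound 1 to compound 2 (0.22 log units; within the scatter) for hydroxy in place of hydrogen, stays within the scatter, and no measured compound carries a methoxy group. No step beyond the scatter is therefore expected in this assay and the estimated step is a 1.2-fold higher number from compound 2 to compound 3 (0.07 log units; within the scatter) with wide uncertainty. Compound 3 is expected at 9000 nM within a range of 3000 nM to 25000 nM for now.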

Compound 3, concentration for 50% growth inhibition: 19500 nM
Beside the measured number, compound 3's estimate is 2.2-fold (0.34 log units) below it; the measured number falls inside the stated range.
By their numbers in this assay, from the lowest: compounds 2, 1 and 3 (each within the scatter of the next, the first and the last beyond it).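

Within the data shown here, at this position on the carbon with a double bond to nitrogen, 2,6-dimethoxyphenyl in place of 4-hydroxyphenyl gives the first step beyond the scatter in this assay (a 2.6-fold higher number from compound 2 to compound 3 (0.41 log units; beyond the scatter)). Measured against the unsubstituted phenyl, the same group stays within the scatter (a 1.5-fold higher number from compound 1 to compound 3 (0.19 log units; within the scatter)), so the modest step is seen only against the hydroxy compound. No evidence bears on the origin of this step. The step removes hydroxy and adds two methoxy groups at once, leaving their separate contributions open. From the compounds shown here alone, how an amine or a carboxylic acid on this aromatic ring would read also remains open.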